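Working notes: lengthening the chain on compound 3

The compounds below may be only part of what the source reports. "The series", "measured", "known", "first", "only" and "open" are said of these compounds alone.

compound 1 `CCCSc1nc(Cc2c(F)cccc2Cl)cc(=O)[nH]1`: > 80000 nM
compound 2 `CCCCSc1nc(Cc2c(F)cccc2Cl)cc(=O)[nH]1`: > 76000 nM
compound 3 `CCCSc1nc(Cc2c(F)cccc2Cl)c(C)c(=O)[nH]1`: > 76000 nM

All three readings come from an ADME assay on MT4 cells (Homo sapiens) for activation, read by MTT assay (on this read-out lower numbers stand for higher toxicity in this test and higher numbers for lower toxicity in this test), and each is a limit, not a number. In this assay compound 3 stands at > 76000 nM, which is a limit. Compound 4 `CCCCSc1nc(Cc2c(F)cccc2Cl)c(C)c(=O)[nH]1` differs from compound 3 by methyl in place of hydrogen on a saturated chain carbon, three bonds along the chain from a sulfur. The same change is a step that the two limits leave unreadable from compound 1 to compound 2. The methyl in place of hydrogen on an aromatic carbon is a step that the two limits leave unreadable from compound 1 to compound 3. Neither step gives a size, so no change beyond the usual scatter is expected, and no direction can be read. The expected step is an at least 1.0-fold lower number from compound 3 to compound 4 (0.03 log units; that floor lies within the scatter). For compound 4 the estimated value is 70000 nM, with an expected range of 35000 nM to 100000 nM.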

Compound 4, half-maximal cytotoxic concentration: > 73000 nM
Compound 4 ended at the assay's limit; the forecaster's own chance of this, stated with the estimate: 70%; middle value at least 1.0-fold (0.01 log units) away from the limit.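

In this assay compound 4 gives > 73000 nM, which is a limit. The steps to compound 4 from compound 3 and from compound 2 cannot be read. The compounds shown leave open at what concentration any of them becomes cytotoxic.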